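Chlorophenyl Replaces Fluoronitrophenyl on the Sulfonyl Sulfur

The source may hold more compounds than are shown below. What is called first, only, known or untested is meant among the compounds shown, and "the series" means these compounds.

Compound 2 `Cn1c(=O)c(S(=O)(=O)c2ccc([N+](=O)[O-])cc2F)cc2cnc(Nc3ccc4[nH]ccc4c3)nc21` gives 400 nM in a functional assay on DU-145 cells (Homo sapiens) for inhibition, read by trypan blue exclusion, with a stated time of 72 h (on this read-out lower numbers stand for stronger inhibition and higher numbers for weaker inhibition), the lowest of the two numbers measured, whereas compound 1 `Cn1c(=O)c(S(=O)(=O)Cc2ccc(F)cc2)cc2cnc(Nc3ccc4[nH]ccc4c3)nc21` gives 30000 nM. Going by the values given here, the only measured step, a 75-fold lower number from compound 1 to compound 2 (1.88 log units; beyond the scatter), shows how strongly the group on the sulfonyl sulfur sets the number. Compound 3 `Cn1c(=O)c(S(=O)(=O)c2ccc(Cl)cc2)cc2cnc(Nc3ccc4[nH]ccc4c3)nc21` differs from compound 2 by 4-chlorophenyl in place of 2-fluoro-4-nitrophenyl on a sulfonyl sulfur. Because the step in this assay was a 75-fold lower number from compound 1 to compound 2 (1.88 log units; beyond the scatter) and compound 3 keeps an aromatic group on the sulfonyl sulfur, compound 3 is expected to give a moderately higher number, a step of a 3.8-fold higher number from compound 2 to compound 3 (0.57 log units; beyond the scatter). Compound 3 is estimated at 1500 nM, within 300 nM to 8000 nM.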

Compound 3, half-maximal inhibitory concentration: 250 nM
Compound 3: the middle estimate sits 6.0-fold (0.78 log units) above what was measured, and the stated range ends above it.
By their numbers in this assay, from the lowest: compounds 3 and 2 (each within the scatter of the next); then compound 1.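

In this assay, the second aryl group on the sulfonyl sulfur leaves the number within the scatter, with a 1.6-fold lower number from compound 2 to compound 3 (0.20 log units; within the scatter), so among these compounds the nitro group and fluorine of 2-fluoro-4-nitrophenyl are not needed for a value in this range. The large gap from the benzyl compound recurs with 4-chlorophenyl, with a 120-fold lower number from compound 1 to compound 3 (2.08 log units; beyond the scatter), so it is not confined to a single aryl group. Nothing measured here explains these numbers. Still open, from the compounds shown here alone, is whether an unsubstituted phenyl, a pyridyl ring or a 4-methoxyphenyl on the sulfonyl sulfur would stay in this range. Equally open, going by these compounds, is how an amine-bearing phenyl would behave there.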